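Notes on the Propoxy Step from Compound 2

The compounds below may be only part of what the source reports. "The series", "measured", "known", "first", "only" and "open" are said of these compounds alone.

Two compounds of the series have been run in a functional assay on HL-60 cells (Homo sapiens) for activation, read by flow cytometry, with a stated time of 4 days; a higher number here means that more compound is needed for the effect, a lower number that less compound is needed. Compound 1, `Cc1cc(F)ccc1-c1cc2c(cn1)ncn2CC1CC1`, gives only a limit of the assay, > 30000 nM, and so no number. Compound 2, `Fc1ccc(-c2cc3c(cn2)ncn3-c2ccc(OC(F)F)cc2)cc1`, gives 10000 nM in this assay. Going by the values given here, this is the only number recorded. The other value shown sits at the limit, (the limit of > 30000 nM in this assay, at which 1 of the 2 values shown sits). Compound 2 is therefore the sole anchor for any further comparison in the series.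

Compound 3, `CCCOc1cc(F)ccc1-c1cc2c(cn1)ncn2-c1ccc(OC(F)F)cc1`, has not yet been measured in this assay. It differs from compound 2 in one place: propoxy in place of hydrogen on an aromatic carbon. Among the compounds with values here, no measured pair carries this change, so its effect in this assay is untested.

The expectation for a 2.0-fold lower number from compound 2 to compound 3 (0.30 log units; within the scatter) is a modest move toward a lower number, of a size that may not clear the usual scatter. Compound 3 is thus expected to give 5000 nM in this assay. The expected range for compound 3 runs from 1500 nM to 20000 nM. Compound 2 gives 10000 nM. Within the data shown here, this is the only number from which to work.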

Compound 3, half-maximal effective concentration: 58 nM
The estimate for compound 3 lay 86-fold (1.94 log units) above the measured number; measured number outside the range, below it.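

In this assay, going by these compounds alone, propoxy in place of hydrogen on an aromatic carbon, ortho to a large group and meta to a fluoro group, gives a 170-fold lower number from compound 2 to compound 3 (2.24 log units; beyond the scatter), the first step that can be read. Within the data shown here, the earlier compounds offered no readable pair, so this is the first sign that this carbon of the six-membered aromatic ring responds strongly to substitution, with a single change moving the number well beyond the scatter. No measurement at hand accounts for the size of this step.

With one pair, the compounds shown do not separate an effect specific to propoxy from what any other group at this carbon might do, and methoxy, a longer chain such as butoxy, or an amine at the same place would help tell these readings apart. Among these compounds, also open is whether the step carries over when the difluoromethoxy-bearing aromatic ring of compounds 2 and 3 gives way to the cyclopropylmethyl group of compound 1, since that comparison rests on no pair differing in one place.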